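From pyridin-2-yl to 3-carboxyphenyl: an expected outcome

This account rests on a few compounds, and the source may have more. Where it says the series, first, only, none or still open, it means among the compounds named here.

Three measured compounds share one core and differ only in the group on an aromatic carbon. Compound 1 `CCCCCCCCc1ccc(OCC(=O)Cn2nnc(SC)n2)cc1` carries methylsulfanyl there; in an assay on microsomes from brain for inhibition of Fatty-acid amide hydrolase 1 (Rattus norvegicus), read by fluorescence and HPLC, with a stated time of 60 min (on this read-out higher numbers stand for weaker inhibition and lower numbers for stronger inhibition), compound 1 gives 31 nM. Compound 2 `CCCCCCCCc1ccc(OCC(=O)Cn2nnc(-c3ccccc3Cl)n2)cc1` carries 2-chlorophenyl, and in this assay compound 2 gives 32 nM. Compound 3 `CCCCCCCCc1ccc(OCC(=O)Cn2nnc(-c3ccccn3)n2)cc1` carries pyridin-2-yl, and in this assay compound 3 gives 18 nM. Compound 3 shows the lowest of the three numbers, yet a 1.7-fold lower number from compound 1 to compound 3 (0.24 log units; within the scatter) and a 1.8-fold lower number from compound 2 to compound 3 (0.25 log units; within the scatter) both fall within the scatter, as does a 1.0-fold higher number from compound 1 to compound 2 (0.01 log units; within the scatter), so no ordering can be read among the three.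

Compound 4 `CCCCCCCCc1ccc(OCC(=O)Cn2nnc(-c3cccc(C(=O)O)c3)n2)cc1` is the unmeasured partner. It differs from compound 3 in one place: 3-carboxyphenyl in place of pyridin-2-yl on an aromatic carbon. All three measured steps bear on this change, since each swaps the group at the same position, and none moved the number beyond the scatter. The new group departs further from anything already seen, so the expected range is wider. Compound 4 is therefore expected to give 35 nM in this assay, most likely between 10 nM and 150 nM. This amounts to an expected step of a 1.9-fold higher number from compound 3 to compound 4 (0.29 log units; within the scatter).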

Compound 4, half-maximal inhibitory concentration: 36 nM
Compound 4: middle estimate off by 1.0-fold (0.01 log units), on the low side; measured number inside the range.
By their numbers in this assay, from the lowest: compounds 3, 1, 2 and 4 (each within the scatter of the next).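

The group that enters is larger than pyridin-2-yl and brings a hydrogen-bond donor that pyridin-2-yl lacks, and it carries a carboxylic acid, unlike the three earlier groups. Even so, a 2.0-fold higher number from compound 3 to compound 4 (0.30 log units; within the scatter) and a 1.1-fold higher number from compound 2 to compound 4 (0.05 log units; within the scatter) and a 1.2-fold higher number from compound 1 to compound 4 (0.06 log units; within the scatter) in this assay show no step that can be read as a real change. This carbon of the five-membered ring, between two ring nitrogen atoms, has now held four quite different groups with no ordering among them, and nothing measured here says why the numbers stay so close.

Still open, on these data alone, is whether a plain phenyl or the methyl ester of the acid would also stay within the scatter. Also open, as far as these compounds go, is whether a group without an aromatic ring, such as an amine or a longer chain, would do the same.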